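Removing the cyano group from compound 3

The source may report more compounds than this note shows. Statements on the series, on what has been measured and on what is new or still open speak of the compounds shown alone.

Three compounds have been run in a functional assay on KB cells (Homo sapiens) for inhibition, read by MTT assay, with a stated time of 24 h, tested at 5 uM; a higher number here means more inhibition of growth at the concentration tested, a lower number less inhibition of growth. Compound 1 `CS(=O)(=O)c1ccc(-c2cnc3[nH]cc(-c4nnc(-c5ccc(F)cc5)o4)c(=O)c3c2)cc1` gives 2.55%; compound 2 `CS(=O)(=O)c1ccc(-c2cnc3[nH]cc(-c4nnc(-c5ccc(Cl)cc5)o4)c(=O)c3c2)cc1` gives 2.15%; compound 3 `N#Cc1ccc(-c2cnc3[nH]cc(-c4nnc(-c5ccc(Cl)cc5)o4)c(=O)c3c2)cc1` gives 7.35%. Compound 3 holds the highest of the three numbers, but its gaps to compound 1 and to compound 2 lie within the scatter, so no order among them can be read. The measured steps are a number 0.4 percentage points lower from compound 1 to compound 2 (within the scatter) and a number 5.2 percentage points higher from compound 2 to compound 3 (within the scatter); only the second touches the aryl substituent that changes next. Compound 4 `O=c1c(-c2nnc(-c3ccc(Cl)cc3)o2)c[nH]c2ncc(-c3ccccc3)cc12` differs from compound 3 by hydrogen in place of cyano on an aromatic carbon. Because swapping methylsulfonyl for cyano produced only a number 5.2 percentage points higher from compound 2 to compound 3 (within the scatter), removing cyano is expected to leave this assay unchanged beyond the scatter, the expected step being a number 2.9 percentage points lower from compound 3 to compound 4 (within the scatter). Compound 4 is therefore estimated at 4.5%, with a range from -5% to 14%.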

Compound 4, percent growth inhibition at one concentration: 2.15%
Estimate against measurement, compound 4: 2.4 percentage points above; the range from low to high includes it.
By their numbers in this assay, from the lowest: compounds 2, 4, 1 and 3 (each within the scatter of the next).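

Removing the substituent altogether gives a number 5.2 percentage points lower from compound 3 to compound 4 (within the scatter) in this assay, and hydrogen in place of methylsulfonyl gives no change at the digits printed from compound 2 to compound 4 (within the scatter), so the unsubstituted phenyl now serves as a reference for this site. On this aromatic carbon para to a large group, hydrogen, cyano and methylsulfonyl cannot be told apart at this single concentration. Nothing available explains this reading. As far as these compounds go, whether an amine or a carboxylic acid at this carbon would shift the number beyond the scatter remains open. So does whether the three groups stay indistinguishable at other concentrations.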